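Swapping Oxygen for Sulfur in Compound 3

The source may hold more compounds than are shown below. What is called first, only, known or untested is meant among the compounds shown, and "the series" means these compounds.

Compound 3 `CC(C)[C@H](NC(=O)COc1cccc2ccccc12)C(=O)N[C@@H](CC(=O)O)C(=O)COc1nccc(C(F)(F)F)n1` gave no number in a functional assay on Jurkat cells (Homo sapiens) for inhibition; a higher number here means a weaker inhibitor, a lower number a stronger inhibitor: its value > 200000 nM is a limit of the assay. Compound 1 `CC(C)[C@H](NC(=O)COc1cccc2ccccc12)C(=O)N[C@@H](CC(=O)O)C(=O)COc1ccccn1` likewise sits at a limit with > 200000 nM. Compound 2 `CC(C)[C@H](NC(=O)COc1cccc2ccccc12)C(=O)N[C@@H](CC(=O)O)C(=O)COc1cc(C(F)(F)F)ncn1` also sits at a limit with > 200000 nM. The steps a step that the two limits leave unreadable from compound 1 to compound 2, a step that the two limits leave unreadable from compound 1 to compound 3 and a step that the two limits leave unreadable from compound 2 to compound 3 therefore cannot be read, as the limit of > 200000 nM in this assay, at which 3 of the 3 values shown sit, shows. Compound 4 `CC(C)[C@H](NC(=O)COc1cccc2ccccc12)C(=O)N[C@@H](CC(=O)O)C(=O)CSc1nccc(C(F)(F)F)n1` differs from compound 3 by (4-(trifluoromethyl)pyrimidin-2-yl)sulfanyl in place of (4-(trifluoromethyl)pyrimidin-2-yl)oxy on a saturated chain carbon bound to a carbonyl carbon. Among the compounds with values here, no measured step bears on this change, so nothing points to a gain or a loss beyond the scatter in this assay. Compound 4 is therefore expected to come out near 200000 nM, between 50000 nM and 1000000 nM, most probably again as a limit. The expected step of a number no higher from compound 3 to compound 4 (the limit leaves the size open) is estimated to be essentially none.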

Compound 4, half-maximal inhibitory concentration: > 200000 nM
Compound 4 was reported as a limit; the forecaster's own chance of this, stated with the estimate: 85%; the middle value lies on the limit itself.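

Compound 4 also sits at a limit of the assay, like compound 1, compound 2 and compound 3, so no step among these four can be read: the limit of > 200000 nM in this assay, at which 4 of the 4 values shown sit. From the compounds shown here alone, what stays open is whether the sulfanyl or oxy link, or the choice of ring, changes the result in this assay at all.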